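Swapping the aryl amine in a urea series

The source may report more compounds than this note shows. Statements on the series, on what has been measured and on what is new or still open speak of the compounds shown alone.

Measured so far:
- compound 1 `CCc1ccc(Nc2cc(NC(=O)Nc3cc(OC)cc(OC)c3)ncn2)cc1`: 50.1%
- compound 2 `COc1ccc(Nc2cc(NC(=O)Nc3c(Cl)cccc3Cl)ncn2)cc1C`: 50%
- compound 3 `COc1ccc(C(F)(F)F)cc1Nc1cc(NC(=O)Nc2c(Cl)cccc2Cl)ncn1`: 60.1%

The three compounds were tested in a functional assay on NCI-H226 cells (Homo sapiens) for inhibition, read by MTT assay, with a stated time of 48 h, tested at 10 uM; on this read-out higher numbers stand for more inhibition at the one concentration tested (going by the name of the read-out) and lower numbers for less inhibition. Compound 1 gives 50.1%, compound 2 gives 50%, and compound 3 gives 60.1%. The number for compound 1 lies within the usual scatter of both of the others, so none of the three can be told apart on this read-out; their values simply sit close together.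

Compound 4 `COc1cc(NC(=O)Nc2cc(Nc3cc(I)ccc3OC)ncn2)cc(OC)c1` shares the core of compound 1 but carries a different group on the aryl amine. The change is 5-iodo-2-methoxyphenyl in place of 4-ethylphenyl on a nitrogen on an aromatic ring. Among the compounds with values here, no measured pair differs in just this way, so there is no step to lean on. Within the data shown here, the three numbers known so far stay close despite quite different substituents on both ends of the shared core, so the expected step is estimated as a number 4.9 percentage points higher from compound 1 to compound 4 (within the scatter), a step expected to fall within the scatter rather than beyond it. Compound 4 is therefore estimated at 55%, with a range from 35% to 75%.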

Compound 4, a percentage reported as inhibition, at one concentration (the size of the read-out at that concentration, not a potency): 56.7%
Beside the measured number, compound 4's estimate is 1.7 percentage points below it; the measured number falls inside the stated range.
By their numbers in this assay, from the lowest: compounds 2, 1, 4 and 3 (each within the scatter of the next, the first and the last beyond it).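

Within the data shown here, this is the first pair that differs in one place only, so the aryl amine can now be read on its own in this assay: 5-iodo-2-methoxyphenyl in place of 4-ethylphenyl on the nitrogen gives a number 6.6 percentage points higher from compound 1 to compound 4 (within the scatter). Even with an iodine and a methoxy group entering, and a hydrogen-bond acceptor gained by count, compound 1 and compound 4 cannot be told apart at the single concentration tested. No measured evidence bears on this result.

The compounds shown leave open whether a quite different group on this nitrogen, such as a carboxylic acid or a chain ending in an amine, would give a step beyond the scatter. On these data alone, it also remains open whether this same swap would read alike with the other end of the urea found in compound 2.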